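This account rests on a few compounds, and the source may have more. Where it says the series, first, only, none or still open, it means among the compounds named here.

In an ADME assay on a cell-free system (plasma, Homo sapiens) for metabolic stability, tested at 1 uM (a lower number here means that the compound disappears faster, a higher number that the compound lasts longer), three compounds have been measured so far. Compound 1 `C=CC(=O)N[C@H]1CCN(S(=O)(=O)c2ccc(NC(=O)OCc3ccccc3)cc2)C1` gives > 6 h, which is a limit of the assay and not a number. Compound 2 `C=CC(=O)NC1CN(S(=O)(=O)c2ccc(NC(=O)OCc3ccccc3)cc2)C1` gives > 6 h, again a limit. Compound 3 `C=CC(=O)NC1CCN(S(=O)(=O)c2ccc(C(=O)NCc3ccccc3)cc2)CC1` gives > 6 h, also a limit. Compound 3 therefore stands with the other two, at the limit of > 6 h in this assay, at which 3 of the 3 values shown sit.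

Compound 4 `C=CC(=O)NC1CCN(S(=O)(=O)c2ccc(C(=O)N(C)Cc3ccccc3)cc2)CC1` differs from compound 3 by methyl in place of hydrogen on an amide-type nitrogen. Among the measured compounds shown here, no measured step involves this change. For the measured compounds named here, the only step available is a step that the two limits leave unreadable from compound 1 to compound 2, so no size can be carried over from it.

The expectation therefore rests on compound 3 with its > 6 h, a limit, and on the smallness of the change. No clear move in either direction is expected in this assay, and compound 4 will probably be reported as a limit too. The expected step is a step that the limit leaves unreadable from compound 3 to compound 4. For compound 4 the estimated half-life is 8 h, with an expected range from 5 h to 16 h.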

Compound 4, half-life: > 6 h
Compound 4: no number, only a limit; the forecaster's own chance of this, stated with the estimate: 85%; the middle value lies beyond the limit too.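

Compound 3 and compound 4 each give only a limit and not a number, so no size can be read for methyl in place of hydrogen on an amide-type nitrogen. How long compounds 1 to 4 actually last in this assay, and whether they differ at all, stays open, because all of them sit at one limit: the limit of > 6 h in this assay, at which 4 of the 4 values shown sit.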